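The source may hold more compounds than are shown below. What is called first, only, known or untested is meant among the compounds shown, and "the series" means these compounds.

Compound 3, with the structure `Cc1ccccc1-c1nn(-c2cc(F)ccc2F)cc1CNCCN1CCN(C)CC1`, stands at > 20000 nM in an ADME assay on Huh-7 cells (Homo sapiens) for cytotoxicity (a higher number here means that more compound is tolerated, a lower number that less compound is tolerated), and this figure is a limit of the assay rather than a measured number. Compound 2, with the structure `Cc1ccccc1-c1nn(-c2ccc(N)cc2)cc1CNCCN1CCN(C)CC1`, also returns a limit in this assay, namely > 20000 nM. Only compound 1, with the structure `Cc1ccccc1-c1nn(-c2ccc(OC(F)(F)F)cc2)cc1CNCCN1CCN(C)CC1`, gives a true number in this assay, 17000 nM. The two readable steps are small: an at least 1.1-fold higher number from compound 1 to compound 2 (0.07 log units; that floor lies within the scatter) and an at least 1.1-fold higher number from compound 1 to compound 3 (0.07 log units; that floor lies within the scatter). The remaining step, a step that the two limits leave unreadable from compound 2 to compound 3, cannot be sized because of the limit of > 20000 nM in this assay, at which 2 of the 3 values shown sit.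

The change now followed, (4-nitrophenyl in place of 2,5-difluorophenyl on an aromatic nitrogen), gives compound 4, with the structure `Cc1ccccc1-c1nn(-c2ccc([N+](=O)[O-])cc2)cc1CNCCN1CCN(C)CC1`. Among the compounds with values here, none of the measured steps involves 4-nitrophenyl, so the expectation rests only on the observation that varying the aryl group on the aromatic nitrogen has so far moved this assay by no more than the scatter. Compound 4 is therefore expected to sit near or at the same limit, with an estimated step of a number no higher from compound 3 to compound 4 (the limit leaves the size open). Compound 4 is estimated at 20000 nM, within the range 9000 nM to 45000 nM.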

Compound 4, half-maximal cytotoxic concentration: > 20000 nM
Compound 4 was reported as a limit (the forecaster's own chance of this, stated with the estimate: 60%); the middle value sits exactly at the limit.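

Within the data shown here, with 4-nitrophenyl, a third group on the aromatic nitrogen reaches the limit in this assay, and this group brings in a nitro substituent unlike any in the earlier compounds. Among these compounds, the one step that can be read is an at least 1.1-fold higher number from compound 1 to compound 4 (0.07 log units; that floor lies within the scatter), so this step shows only a floor and no difference beyond the scatter. The steps among compound 2, compound 3 and compound 4 cannot be read because all three stop at the same limit: the limit of > 20000 nM in this assay, at which 3 of the 4 values shown sit.

On these data alone, it remains open how far beyond that limit compound 2, compound 3 and compound 4 lie, and whether any of them truly differs from compound 1. As far as these compounds go, it is also open whether a carboxylic acid or a longer alkyl chain on that phenyl ring would give a true number.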